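A few compounds are considered here, and "the series" means these few. Any claim that something is new, unique, unknown or untested is made for them only; others in the source may bear on it.

Of the compounds shown here, three of one shared core have been tested in a functional assay on DLD-1 cells (Homo sapiens) for cytotoxicity, read by WST assay, with a stated time of 72 h; a higher number here means a weaker inhibitor, a lower number a stronger inhibitor. Compound 2, `COc1cc2c(Nc3nc4ccc(C(=O)Nc5c(C)cccc5Cl)cc4s3)ncnc2cc1OCCCN1CCCCC1`, gives 14700 nM. Compound 1, `COc1cc2c(Nc3nc4ccc(C(=O)Nc5c(C)cccc5Cl)cc4s3)ncnc2cc1OCCCN1CCCC1`, gives 60700 nM. Compound 3, `COc1cc2c(Nc3nc4ccc(C(=O)Nc5c(C)cc(C)cc5C)cc4s3)ncnc2cc1OCCCN1CCCCC1`, gives 24500 nM. Compound 3 differs from compound 2 in one place: 2,4,6-trimethylphenyl in place of 2-chloro-6-methylphenyl on an amide-type nitrogen. That change gave a 1.7-fold higher number from compound 2 to compound 3 (0.22 log units; within the scatter), so compounds 2 and 3 cannot be told apart in this assay.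

Compound 1 differs from compound 2 in a different place: pyrrolidin-1-yl in place of piperidin-1-yl on a saturated chain carbon, three bonds along the chain from an oxygen on an aromatic ring. This step gave a 4.1-fold higher number from compound 2 to compound 1 (0.62 log units; beyond the scatter), a clear weakening.

Compound 4, `COc1cc2c(Nc3nc4ccc(C(=O)Nc5c(C)cc(C)cc5C)cc4s3)ncnc2cc1OCCCN1CCCC1`, has not yet been measured. It differs from compound 3 by pyrrolidin-1-yl in place of piperidin-1-yl on a saturated chain carbon, three bonds along the chain from an oxygen on an aromatic ring, the same change that leads from compound 2 to compound 1, at the same place; the two pairs differ only in the ring on the amide-type nitrogen described above. Going by the values given here, since the one time this change was measured it gave a 4.1-fold higher number from compound 2 to compound 1 (0.62 log units; beyond the scatter), a step of similar size is expected from compound 3, whose value is 24500 nM, so that compound 4 is expected to show a 3.9-fold higher number from compound 3 to compound 4 (0.59 log units; beyond the scatter). The estimate for compound 4 is therefore 95000 nM, expected to lie between 40000 nM and 220000 nM, resting on one example of the change only.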

Compound 4, half-maximal inhibitory concentration: 5900 nM
The estimate for compound 4 lay 16-fold (1.21 log units) above the measured number, and the stated range ends above it.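

In this assay, replacing piperidin-1-yl with pyrrolidin-1-yl did not carry over from one core to the other: it gave a 4.2-fold lower number from compound 3 to compound 4 (0.62 log units; beyond the scatter), the opposite direction to the earlier step, and the two steps disagree: the same change on two cores in this assay, a 4.1-fold higher number (0.62 log units; beyond the scatter) from compound 2 to compound 1 and a 4.2-fold lower number (0.62 log units; beyond the scatter) from compound 3 to compound 4, 17-fold (1.23 log units) apart, beyond the scatter of two such steps

Changing the ring on the amide-type nitrogen to 2,4,6-trimethylphenyl also depended on its partner, giving a 10-fold lower number from compound 1 to compound 4 (1.01 log units; beyond the scatter) when pyrrolidin-1-yl was present, a different result from the step measured with piperidin-1-yl: the same change on two cores in this assay, a 1.7-fold higher number (0.22 log units; within the scatter) from compound 2 to compound 3 and a 10-fold lower number (1.01 log units; beyond the scatter) from compound 1 to compound 4, 17-fold (1.23 log units) apart, beyond the scatter of two such steps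

This shows that, among these four compounds, the two changes do not add up independently, so a step measured on one core cannot safely be transferred to the other; it does not show why they interact or how widely this holds, since each comparison rests on a single pair of steps.

The compounds shown leave open whether the reversal is particular to pyrrolidin-1-yl. A morpholine ring or a dimethylamino group at the end of the chain, or a longer chain, could test whether other amines behave in the same way.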